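The source may hold more compounds than are shown below. What is called first, only, known or untested is meant among the compounds shown, and "the series" means these compounds.

In an ADME assay on a cell-free system (plasma, Mus musculus) for metabolic stability, read by LC-MS, tested at 2 uM (a lower number here means that the compound disappears faster, a higher number that the compound lasts longer), compound 1 (`CCOCCNC(=O)n1cc(-c2ccccc2)oc1=O`) gives 1.33 h and compound 2 (`O=C(NCCCCc1ccccc1)n1cc(-c2ccc(F)cc2)oc1=O`) gives 1.5 h. These two values lie within the usual scatter of each other, so compound 2 stands level with compound 1. Compound 3 (`O=C(NCCCCc1ccccc1)n1cc(-c2ccccn2)oc1=O`) has pyridin-2-yl in place of 4-fluorophenyl on an aromatic carbon of compound 2: pyridin-2-yl in place of 4-fluorophenyl on an aromatic carbon. For the measured compounds named here, no measured pair of compounds shows what a change in one place does here, so the main guide is compound 2 at 1.5 h. The expected change, a 1.3-fold lower number from compound 2 to compound 3 (0.10 log units; within the scatter), is a small one in the downward direction, not beyond the scatter. For compound 3 the estimated half-life is 1.2 h, with an expected range of 0.5 h to 3 h.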

Compound 3, half-life: 0.667 h
Beside the measured number, compound 3's estimate is 1.8-fold (0.26 log units) above it; measured number inside the range.
By their numbers in this assay, from the lowest: compounds 3, 1 and 2 (each within the scatter of the next, the first and the last beyond it).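

In this assay, for the compounds shown here, the swap of 4-fluorophenyl for pyridin-2-yl gives a 2.2-fold lower number from compound 2 to compound 3 (0.35 log units; beyond the scatter) and is the first change in one place that can be read, showing that the half-life responds to the group at this position. The step is modest, but it lies beyond the usual scatter. No measurement shown accounts for the drop. The ring nitrogen enters and the fluorine leaves in the same step, and the compounds shown do not separate the two. On these data alone, how pyridin-3-yl or 4-methoxyphenyl would fare at this position remains open.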